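This account rests on a few compounds, and the source may have more. Where it says the series, first, only, none or still open, it means among the compounds named here.

Compound 1 `Nc1ncn(C/C=C2\OC(=O)C(OCc3ccccc3)=C2OCc2ccccc2)c(=O)n1` and compound 2 `O=C1O/C(=C\Cn2ccc(NC(=O)c3ccccc3)nc2=O)C(OCc2ccccc2)=C1OCc1ccccc1` share the same core, each carrying a pendant base on a linker. In a functional assay on HeLa cells (Homo sapiens) for inhibition, read by MTT assay, with a stated time of 72 h (on this read-out lower numbers stand for stronger inhibition and higher numbers for weaker inhibition), compound 1 gives 5910 nM. In this assay compound 2 gives 7200 nM. Compound 3 `NC1(CCn2cc(F)c(=O)[nH]c2=O)OC(=O)C(OCc2ccccc2)=C1OCc1ccccc1` carries its base on a different linker and bears an amine on the core. In this assay compound 3 reaches only a limit of the assay, > 100000 nM, so no number is known for it; this is the limit of > 100000 nM in this assay, at which 1 of the 3 values shown sits. Thus compound 1 and compound 2 give numbers, while compound 3 stands at the limit.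

Compound 4 `Cc1cn(CCC2(N)OC(=O)C(OCc3ccccc3)=C2OCc2ccccc2)c(=O)[nH]c1=O` differs from compound 3 in one place: methyl in place of fluoro on an aromatic carbon. Among the compounds with values here, no measured pair showing this change exists here. A change of one heavy atom for one heavy atom is expected to move the read-out by no more than the usual scatter in this assay, so compound 4 is expected to stay close to where compound 3 sits, a step that the limit leaves unreadable from compound 3 to compound 4. Compound 4 is therefore estimated at 150000 nM in this assay, with an expected range from 50000 nM to 500000 nM, and the assay is expected most likely to report only a limit again.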

Compound 4, half-maximal inhibitory concentration: > 100000 nM
Compound 4: a limit, no number; the forecaster's own chance of this, stated with the estimate: 75%; the middle value lies beyond the limit too.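

Compound 3 and compound 4 both stop at a limit of this assay and give no number, so the step between them cannot be read: the limit of > 100000 nM in this assay, at which 2 of the 4 values shown sit.

The compounds shown leave open whether methyl in place of fluoro on an aromatic carbon changes inhibition at all, since neither compound gives a number to compare.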